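Fluoro Added to a Second Core: Expected Cytotoxicity

This account rests on a few compounds, and the source may have more. Where it says the series, first, only, none or still open, it means among the compounds named here.

Compound 1 `N/C(=N\NC(=S)N1CCCCCC1)c1ccccn1` and compound 2 `N/C(=N\NC(=S)N1CCSCC1)c1ccccn1` share a thiourea-like linker but differ in the ring attached to it; the difference between the two cores is not broken down here. In a functional assay on MCF7 cells (Homo sapiens) for cytotoxicity, read by MTT assay, with a stated time of 72 h, tested at 3 uM (on this read-out lower numbers stand for less inhibition of growth and higher numbers for more inhibition of growth at the one concentration tested), compound 1 gives 56%, while compound 2 gives 29%. Compound 3 `N/C(=N\NC(=S)N1CCSCC1)c1ccc(F)cn1` arises from compound 2 by fluoro in place of hydrogen on an aromatic carbon. In this assay compound 3 gives 35.4%, so that the step of a number 6.4 percentage points higher from compound 2 to compound 3 (within the scatter) stays within the scatter. Compound 4 `N/C(=N\NC(=S)N1CCCCCC1)c1ccc(F)cn1` carries the same change on the core of compound 1, namely (fluoro in place of hydrogen on an aromatic carbon). Because the measured step of a number 6.4 percentage points higher from compound 2 to compound 3 (within the scatter) was small, the step from compound 1 to compound 4 is expected to be of similar size, a number 4 percentage points higher from compound 1 to compound 4 (within the scatter). Compound 4 is therefore estimated to give about 60%, likely between 45% and 75%.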

Compound 4, percent growth inhibition at one concentration: 24.3%
Estimate against measurement, compound 4: 35.7 percentage points above, outside the stated range (below it).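

In this assay fluoro in place of hydrogen on an aromatic carbon gives a large step on the second core, a number 31.7 percentage points lower from compound 1 to compound 4 (beyond the scatter). Carried from one core to the other, the same change does not give the same step: the same change on two cores in this assay, a number 6.4 percentage points higher (within the scatter) from compound 2 to compound 3 and a number 31.7 percentage points lower (beyond the scatter) from compound 1 to compound 4, 38.1 percentage points apart, beyond the scatter of two such steps. This shows that, for these two cores, the step measured on one did not predict the step on the other, but it does not show why they differ, and two cores give no rule for any further core in the series.

The compounds shown leave open whether a chloro or a methoxy group in that place would also differ between the two cores. They also leave open how an amine there would behave on either core.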